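Oxan-4-yl in place of phenyl on a carbonyl carbon

The compounds below may be only part of what the source reports. "The series", "measured", "known", "first", "only" and "open" are said of these compounds alone.

In a physicochemical assay for lipophilicity, read by HPLC, measured as chromatographic lipophilicity, at pH 7.4 (a lower number here means a more polar compound, a higher number a more lipophilic compound), compound 1 `O=C(C1CCC1)N1N=CCC1c1ccccc1` gives 4.7 while compound 2 `O=C(c1ccccc1)N1N=CCC1c1ccccc1` gives 4.6 and the two cannot be told apart. Compound 3 `O=C(C1CCOCC1)N1N=CCC1c1ccccc1` shares their core and carries oxan-4-yl in place of phenyl on a carbonyl carbon, a change counted as oxan-4-yl in place of phenyl on a carbonyl carbon and not yet measured.

Among the compounds with values here, the only measured step that bears on it is a number 0.10 log units lower from compound 1 to compound 2 (within the scatter) with phenyl in place of cyclobutyl on a carbonyl carbon. Both groups in that step are built of carbon alone, whereas oxan-4-yl brings in oxygen and a hydrogen-bond acceptor. Within the data shown here, that step is therefore a weak guide, and no measurement yet covers this kind of swap.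

Resting on the structural change alone, and taking compound 2 at 4.6 as the starting point, a move to a lower number beyond the scatter is expected in this assay for this swap. The estimate is a number 0.90 log units lower from compound 2 to compound 3 (beyond the scatter) and it remains uncertain. Compound 3 is expected at 3.7 within an estimated range of 3.2 to 4.2 on this scale.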

Compound 3, distribution coefficient: 3.1
For compound 3 the middle estimate is 0.60 log units above the measured one; the whole stated range lies above it.
By their numbers in this assay, from the lowest: compound 3; then compounds 2 and 1 (each within the scatter of the next).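

The position on the carbonyl carbon proves far from indifferent in this assay: swapping one carbon-only group for another gave a number 0.10 log units lower from compound 1 to compound 2 (within the scatter), while oxan-4-yl gives both a number 1.50 log units lower from compound 2 to compound 3 (beyond the scatter) and a number 1.60 log units lower from compound 1 to compound 3 (beyond the scatter). Phenyl and oxan-4-yl each count 6 heavy atoms, so the large step from compound 2 comes without any change in that count, and what differs is that a six-membered aromatic ring of carbon only leaves while a non-aromatic ring with one oxygen and one hydrogen-bond acceptor enters. No supporting measurement is available to explain why the number drops this far.

The compounds shown change the ring oxygen and the loss of the aromatic ring together, so they cannot say how much of the step belongs to each, and a cyclohexyl group, which keeps the non-aromatic ring of oxan-4-yl but has carbon in place of its oxygen, would be the direct test. From the compounds shown here alone, how a piperidin-4-yl group, with nitrogen in that ring, or a carboxylic acid at this position would read on the same scale also stays open.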